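Cytotoxicity of a dimethoxyphenyl hydrazone analogue

A few compounds are considered here, and "the series" means these few. Any claim that something is new, unique, unknown or untested is made for them only; others in the source may bear on it.

Three hydrazones built on one shared core have been tested in an ADME assay on MT4 cells (Homo sapiens) for cytotoxicity, read by MTT assay; on this read-out higher numbers stand for lower toxicity in this test and lower numbers for higher toxicity in this test. Compound 1 `O=C(CSc1nnnn1-c1cccc2ccccc12)N/N=C/c1ccco1` carries a furan-2-yl group on the carbon with a double bond to nitrogen, and in this assay compound 1 gives > 330000 nM, which is a limit of the assay and not a number. Compound 2 `O=C(CSc1nnnn1-c1cccc2ccccc12)N/N=C/c1cccc(Cl)c1` carries a 3-chlorophenyl group there, and in this assay compound 2 gives 240000 nM. Compound 3 `COc1ccc(/C=N/NC(=O)CSc2nnnn2-c2cccc3ccccc23)cc1` carries a 4-methoxyphenyl group, and in this assay compound 3 gives > 298000 nM, again a limit of the assay rather than a number. Compound 3 thus stands at a limit, as recorded in the limit of > 298000 nM in this assay, at which 1 of the 3 values shown sits, and compound 1 stands at another, recorded in the limit of > 330000 nM in this assay, at which 1 of the 3 values shown sits. The measured steps are an at least 1.3-fold lower number from compound 1 to compound 2 (0.13 log units; that floor lies within the scatter), an at least 1.2-fold higher number from compound 2 to compound 3 (0.09 log units; that floor lies within the scatter) and a step that the two limits leave unreadable from compound 1 to compound 3. Compound 4 `COc1cccc(/C=N/NC(=O)CSc2nnnn2-c2cccc3ccccc23)c1OC` differs from compound 3 in one place: 2,3-dimethoxyphenyl in place of 4-methoxyphenyl on a carbon with a double bond to nitrogen. Every measured step here exchanges one aryl group for another and comes out small or unreadable, so no step beyond the scatter is expected for compound 4 in this assay. Compound 4 is expected to give about 300000 nM, between 150000 nM and 600000 nM. This estimate corresponds to the expected step that the limit leaves unreadable from compound 3 to compound 4.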

Compound 4, half-maximal cytotoxic concentration: 192000 nM
Compound 4: middle estimate off by 1.6-fold (0.19 log units), on the high side; the range from low to high includes it.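

Placing 2,3-dimethoxyphenyl on the carbon with a double bond to nitrogen gives a measured number rather than a limit in this assay, and the exchange against the 3-chlorophenyl group gives a 1.3-fold lower number from compound 2 to compound 4 (0.10 log units; within the scatter), so these two aryl groups cannot be told apart in this test. Against the other two groups, the exchange gives an at least 1.5-fold lower number from compound 3 to compound 4 (0.19 log units; that floor lies within the scatter) and an at least 1.7-fold lower number from compound 1 to compound 4 (0.23 log units; that floor lies within the scatter), and neither floor shows a step beyond the scatter. The change from 4-methoxyphenyl can be read only as a floor because compound 3 stands at a limit of the assay and not at a number: the limit of > 298000 nM in this assay, at which 1 of the 4 values shown sits.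

How far the value of compound 4 truly lies from that of compound 1 stays open because compound 1 also stands at a limit of the assay and not at a number: the limit of > 330000 nM in this assay, at which 1 of the 4 values shown sits. The compounds shown also leave open how this assay responds when an amine or a carboxylic acid takes the place of the aryl group on this carbon.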